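Swapping Ethyl for Hydroxy in Compound 1

The compounds below may be only part of what the source reports. "The series", "measured", "known", "first", "only" and "open" are said of these compounds alone.

For the measured compounds named here, compound 1 `CCOc1ccc(C(=O)/C=C/c2ccc(CC)cc2)cc1` is the only compound here with a plain number: in an assay on isolated protein for inhibition of Amine oxidase [flavin-containing] B (Homo sapiens) (a higher number here means a weaker inhibitor, a lower number a stronger inhibitor), compound 1 gives 210 nM. The two other compounds give only limits. Compound 2 `O=C(/C=C/c1ccccc1F)c1ccc(-n2ccnc2)cc1` reaches only > 10000 nM in this assay, which is a limit and not a number. Compound 3 `COc1ccc(C(=O)/C=C/c2ccc(O/N=C(\C)c3ccc(OC)cc3)cc2)cc1` likewise stops at the limit of > 200 nM. Going by the values given here, no two measured compounds differ in only one place, so no measured step is available. Compound 4 `CCOc1ccc(C(=O)/C=C/c2ccc(O)cc2)cc1` differs from compound 1 by hydroxy in place of ethyl on an aromatic carbon. Among the compounds with values here, with no measured step to lean on, the expectation is that this change weakens inhibition moderately, by a step of a 4.8-fold higher number from compound 1 to compound 4 (0.68 log units; beyond the scatter) beyond the usual scatter. Compound 4 is therefore estimated at 1000 nM, expected to fall between 300 nM and 4000 nM.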

Compound 4, half-maximal inhibitory concentration: 210 nM
Compound 4: the middle estimate sits 4.8-fold (0.68 log units) above what was measured, outside the stated range (below it).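

Putting hydroxy in place of ethyl, on an aromatic carbon para to a large group, gives no change at the digits printed from compound 1 to compound 4 (within the scatter) in this assay. In this one pair, the position accepts a group with a hydrogen-bond donor and a hydrogen-bond acceptor in place of a group with neither, and inhibition holds. Nothing among the data shown explains why the two groups match here.

From the compounds shown here alone, whether an amine, a carboxylic acid or a longer chain would be accepted at this position remains open. So does whether the same swap would give the same result on a different core.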